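Tertiary amide in place of secondary amide on compound 1

The compounds below may be only part of what the source reports. "The series", "measured", "known", "first", "only" and "open" are said of these compounds alone.

Going by the values given here, compound 1 `CCCCNC(=O)C1CCCN(c2nc(N)c3cc(OC)c(OC)cc3n2)C1` is the weaker of the two measured members: in an assay on isolated protein for displacement of a labelled ligand from Adrenergic receptor alpha-1 (Rattus norvegicus) (on this read-out lower numbers stand for stronger inhibition and higher numbers for weaker inhibition), compound 1 gives 8.25 nM. Compound 2 `COc1cc2nc(N3CCC(C(=O)NCC4CC4)CC3)nc(N)c2cc1OC`, which carries its amide on a differently attached saturated ring and a cyclopropylmethylamino group on the carbonyl, gives 0.9 nM in this assay; the gap between the two lies beyond the scatter, but the two structures differ in more than one place, so no single step can be read from them.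

Compound 3 `CCN(CC)C(=O)C1CCCN(c2nc(N)c3cc(OC)c(OC)cc3n2)C1` keeps the core and the saturated ring of compound 1 and differs only at the amide: diethylamino in place of butylamino on a carbonyl carbon. The change rearranges the same atoms and removes the amide hydrogen without adding any new group.

Among the compounds with values here, there is no measured pair that isolates this kind of change, so the expectation rests on compound 1 alone. The step from compound 1 to compound 3 is expected to be small, most likely towards a somewhat higher number, and may well fall within the scatter: a 1.7-fold higher number from compound 1 to compound 3 (0.23 log units; within the scatter). Compound 3 is accordingly estimated at 14 nM in this assay, with a range from 3.5 nM to 55 nM.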

Compound 3, inhibition constant: 117 nM
Estimate against measurement, compound 3: 8.4-fold (0.92 log units) below, outside the stated range (above it).
By their numbers in this assay, from the lowest: compound 2; then compound 1; then compound 3.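

In this assay, the carbonyl carbon on the saturated ring of compound 1 proves sensitive to how the same atoms are arranged: diethylamino in place of butylamino gives a 14-fold higher number from compound 1 to compound 3 (1.15 log units; beyond the scatter). Going by these compounds alone, this is the first single-place step, and it shows that a group with the same heavy-atom count and composition, differing in its attachment and in the loss of the amide hydrogen, is not an equivalent replacement at this position. Nothing available bears on what lies behind the size of this step.

As far as these compounds go, whether the step follows from the loss of the amide hydrogen or from the two ethyl chains replacing a single butyl chain remains open; isobutylamino, which keeps the amide hydrogen, and a methyl group added on the nitrogen of butylamino, which removes it, would help to separate the two. Also open, from the compounds shown here alone, is how smaller or ring-closed tertiary amides, such as dimethylamino or pyrrolidine on the carbonyl, would read at this position, and whether the exchange gives a step of similar size on the saturated ring of compound 2.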